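The compounds below may be only part of what the source reports. "The series", "measured", "known", "first", "only" and "open" are said of these compounds alone.

Among the compounds with values here, in an assay on MDA-MB-231 cells for binding affinity to C-X-C chemokine receptor type 4 (Homo sapiens), read by immunofluorescence and microscopy, with stated times of 10 min and 30 min (a lower number here means that less compound is needed, a higher number that more compound is needed for the effect), compound 1 `O=C(NCc1ccc(CNS(=O)(=O)c2ccccc2)cc1)c1cccc(F)c1` gives 100 nM, which is the second highest of the three numbers so far. Compound 2 `Cc1ccc(S(=O)(=O)NCc2ccc(CNC(=O)c3ccccc3Cl)cc2)cc1` gives 10 nM, and compound 3 `Cc1ccc(S(=O)(=O)NCc2ccc(CNC(=O)c3cccc(C)c3)cc2)cc1` gives 1000 nM. Compound 4 `Cc1ccc(C(=O)NCc2ccc(CNS(=O)(=O)c3ccccc3)cc2)cc1` differs from compound 1 in one place: 4-methylphenyl in place of 3-fluorophenyl on a carbonyl carbon. Within the data shown here, the only measured step that touches this carbonyl-bound ring is a 100-fold higher number from compound 2 to compound 3 (2.00 log units; beyond the scatter), where a methyl-bearing ring replaced a chlorine-bearing one and the number rose sharply. A methyl-bearing ring replacing a fluorine-bearing one might likewise raise the number, though the positions differ, so a modest rise is expected, a 3.0-fold higher number from compound 1 to compound 4 (0.48 log units; beyond the scatter). Compound 4 is therefore estimated at 300 nM, with a likely range from 60 nM to 2000 nM.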

Compound 4, effective concentration (reported as EC, without a stated level of effect): 100 nM
For compound 4 the middle estimate is 3.0-fold (0.48 log units) above the measured one; low and high end bracket the measured number.
By their numbers in this assay, from the lowest: compound 2; then compounds 1 and 4 (each within the scatter of the next); then compound 3.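

In this assay, 4-methylphenyl in place of 3-fluorophenyl on a carbonyl carbon gives no change at the digits printed from compound 1 to compound 4 (within the scatter). A swap of the ring on this carbonyl therefore need not move the number, although the earlier swap there gave a 100-fold higher number from compound 2 to compound 3 (2.00 log units; beyond the scatter). Nothing measured here explains why these two swaps differ. As far as these compounds go, this step changes both the group on the ring and its ring position, so the part played by each alone stays open. Also open, from the compounds shown here alone, is how the number responds to an amine or a carboxylic acid on this ring.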